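The source may hold more compounds than are shown below. What is called first, only, known or untested is meant among the compounds shown, and "the series" means these compounds.

Among the measured compounds shown here, in a functional assay on MCF-10A cells (Homo sapiens) for inhibition (a higher number here means a weaker inhibitor, a lower number a stronger inhibitor), compound 1 `O=C(/C=C/c1ccc(I)cc1)c1ccc(B(O)O)cc1` gives 75000 nM as its half-maximal inhibitory concentration, the higher of the two numbers available so far. For the measured compounds named here, the only other measured compound, compound 2 `O=C(/C=C/c1ccc(Cl)c(Cl)c1)c1ccc(B(O)O)cc1`, gives 18000 nM and is therefore the stronger inhibitor of the pair, by a margin beyond the usual scatter. These two compounds differ in more than one place, so their gap cannot be tied to any single change.

The unmeasured compound 3 `O=C(O)COc1ccc(C(=O)/C=C/c2ccc(I)cc2)cc1` keeps the rest of compound 1 and differs from it by one swap: a group of 5 heavy atoms (2 carbon, 3 oxygen; no ring) in place of a group of 3 heavy atoms (1 boron, 2 oxygen; no ring), on an aromatic carbon on an aromatic carbon, para to a large group. Going by the values given here, no measured pair shows what this swap does, which leaves compound 1 at 75000 nM as the only anchor and makes any forecast loose. A slight rise at most is expected, with no change beyond the scatter, and the estimated move is a 1.2-fold higher number from compound 1 to compound 3 (0.08 log units; within the scatter) in this assay with wide uncertainty. The expected value for compound 3 is 90000 nM with an estimated range from 30000 nM to 250000 nM for now.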

Compound 3, half-maximal inhibitory concentration: 44000 nM
Compound 3: middle estimate off by 2.0-fold (0.31 log units), on the high side; the measured number falls inside the stated range.
By their numbers in this assay, from the lowest: compound 2; then compounds 3 and 1 (each within the scatter of the next).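

Among the compounds shown here, compound 1 and compound 3 are the first measured pair that differ in only one place, which makes this the first direct look at this position, on an aromatic carbon, para to a large group. Putting carboxymethoxy in place of the boron-containing group gives a 1.7-fold lower number from compound 1 to compound 3 (0.23 log units; within the scatter) in this assay, so the two compounds cannot be told apart in this assay, even though the two groups differ in heavy-atom count and composition. Boron at this position is therefore not needed for inhibition at this level when the rest of compound 1 stays the same, and no measurement shown here explains why these two different groups read alike.

This single pair cannot show whether the result is general, including whether the same swap would read alike on the core of compound 2, which carries a different substitution on its other ring. Going by these compounds, it is also open what a plain carboxylic acid, an amine or a longer chain would do at this same position, and whether any of them would move the number beyond the usual scatter.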